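Fluoro for methoxy: compound 2 to compound 3

This account rests on a few compounds, and the source may have more. Where it says the series, first, only, none or still open, it means among the compounds named here.

Compound 1 `COc1ccc(-c2nc(C(=O)/C=C\Nc3ccc4[nH]ccc4c3)c3ccccn23)cc1` in a functional assay on MDA-MB-231 cells (Homo sapiens) for cytotoxicity, read by MTT assay, with a stated time of 48 h (on this read-out lower numbers stand for stronger inhibition and higher numbers for weaker inhibition), gives 28700 nM. Compound 2 `COc1ccc(-c2nc(C(=O)/C=C\Nc3ccc(Cl)cc3)c3ccccn23)cc1` in this assay returns only a limit, > 30000 nM, so for compound 2 no number is known, only that limit. Within the data shown here, the single measured step, an at least 1.0-fold higher number from compound 1 to compound 2 (0.01 log units; that floor lies within the scatter), changes the aryl on the amine nitrogen and ends at the limit described by the limit of > 30000 nM in this assay, at which 1 of the 2 values shown sits. Compound 3 `O=C(/C=C\Nc1ccc(Cl)cc1)c1nc(-c2ccc(F)cc2)n2ccccc12` differs from compound 2 by fluoro in place of methoxy on an aromatic carbon. Among the measured compounds shown here, no measured step touches this position; the one comparison available, an at least 1.0-fold higher number from compound 1 to compound 2 (0.01 log units; that floor lies within the scatter), lies elsewhere in the structure and ends at the limit. The expectation in this assay is therefore no step beyond the scatter, with compound 3 most likely sitting again at or near the limit. Compound 3 is estimated at 35000 nM, within a range of 15000 nM to 80000 nM. The expected step is a step that the limit leaves unreadable from compound 2 to compound 3.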

Compound 3, half-maximal inhibitory concentration: 4250 nM
For compound 3 the middle estimate is 8.2-fold (0.92 log units) above the measured one; measured number outside the range, below it.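

In this assay, the change from 4-methoxyphenyl to 4-fluorophenyl gives an at least 7.0-fold lower number from compound 2 to compound 3 (0.84 log units; beyond the scatter), the only step shown that clears the scatter, so this place, para to a large group, does affect the read-out. With the 4-chlorophenyl group on the amine nitrogen held fixed, compound 3 gives 4250 nM, a measured number for this pair of compounds. The true size of the step stays unknown and its printed size is only a floor, because compound 2 is known only as a limit: the limit of > 30000 nM in this assay, at which 1 of the 3 values shown sits.

From the compounds shown here alone, whether the step depends on fluoro itself or on the loss of methoxy stays open; a trifluoromethyl group or an amine at the same place would help separate the two. Also open, going by these compounds, is whether the step carries over when 1H-indol-5-yl sits on the amine nitrogen.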